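The compounds below may be only part of what the source reports. "The series", "measured", "known", "first", "only" and "open" are said of these compounds alone.

Compound 1 `COC(=O)c1cc(-c2cccc(NC(=O)c3ccc(/C=C/C(=O)c4ccc(C)c(F)c4)cc3)c2)on1` is tested in an ADME assay on Vero cells (Chlorocebus sabaeus) for cytotoxicity, read by MTT assay, with a stated time of 72 h (a higher number here means that more compound is tolerated, a lower number that less compound is tolerated), and gives only a limit, > 50 ug/mL, so its true value is not pinned down; it sits at the limit of > 50 ug/mL in this assay, at which 1 of the 3 values shown sits. Compound 3 `CCOC(=O)c1cc(-c2cccc(NC(=O)c3ccc(/C=C/C(=O)c4ccc(Cl)cc4)cc3)c2)on1` likewise gives only a limit in this assay, > 80 ug/mL, at the limit of > 80 ug/mL in this assay, at which 1 of the 3 values shown sits. Compound 2 `CCOC(=O)c1cc(-c2cccc(NC(=O)c3cccc(C(F)(F)F)c3)c2)on1` has no result in this assay, "not determined" (no result reported). Compound 4 `COC(=O)c1cc(-c2cccc(NC(=O)c3ccc(/C=C/C(=O)c4cccc([N+](=O)[O-])c4)cc3)c2)on1` is not yet measured; it differs from compound 1 by 3-nitrophenyl in place of 3-fluoro-4-methylphenyl on a carbonyl carbon. For the measured compounds named here, both measured values are limits, so no step between measured compounds can be sized. The expected step that the limit leaves unreadable from compound 1 to compound 4 is estimated to be none beyond the scatter, with the assay likely reporting a limit again. For compound 4 the estimated value is 55 ug/mL, between 25 ug/mL and 100 ug/mL.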

Compound 4, half-maximal cytotoxic concentration: > 40 ug/mL
Compound 4 ended at the assay's limit (the forecaster's own chance of this, stated with the estimate: 65%); the middle value lies beyond the limit too.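

Compound 1 and compound 4 both give only limits in this assay, and the step between them cannot be read. The compounds shown leave open whether 3-nitrophenyl in place of 3-fluoro-4-methylphenyl changes tolerance at all.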